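A few compounds are considered here, and "the series" means these few. Any claim that something is new, unique, unknown or untested is made for them only; others in the source may bear on it.

Series notes.

Compound 1 `O=C(CCl)N1CCCC(n2nc(-c3ccc(Oc4ccccc4)cc3)cc2CO)C1`, compound 3 `O=C(O)c1cc(-c2ccc(Oc3ccccc3)cc2)nn1C1CCCN(C(=O)CCl)C1` and compound 2 `C/C=C/C(=O)Nc1cccc(Cn2nc(-c3ccc(Oc4ccccc4)cc3)cc2C(=O)O)c1` have been run in a functional assay on Rec1 cells (Homo sapiens) for inhibition, read by luminescence and CellTiter-Glo, with a stated time of 72 h; on this read-out higher numbers stand for weaker inhibition and lower numbers for stronger inhibition. Compound 1 gives 400 nM, compound 3 gives 2200 nM and compound 2 gives 26000 nM. The cores of compound 2 and compound 3 are not the same; the difference between the two cores is not broken down here. Between compound 3 and compound 1 a single change is made, (hydroxymethyl in place of carboxy on an aromatic carbon), and this step is a 5.5-fold lower number from compound 3 to compound 1 (0.74 log units; beyond the scatter).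

Compound 4 `C/C=C/C(=O)Nc1cccc(Cn2nc(-c3ccc(Oc4ccccc4)cc3)cc2CO)c1` is not yet measured. It carries the same kind of change relative to compound 2, namely (hydroxymethyl in place of carboxy on an aromatic carbon). The two places are not the same word for word: in the earlier pair the ring atom next to the changed carbon bears a 1-((chloromethyl)carbonyl)piperidin-3-yl group, while in compound 2 and compound 4 it bears a large group of another kind. For the measured compounds named here, with only one earlier instance on a different core, the transfer is uncertain. The expected step from compound 2 to compound 4 in this assay is a 4.7-fold lower number from compound 2 to compound 4 (0.67 log units; beyond the scatter), beside the earlier one, resting on compound 3 at 2200 nM and compound 1 at 400 nM. Compound 4 is estimated at 5500 nM, with a range from 1500 nM to 18000 nM.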

Compound 4, half-maximal inhibitory concentration: 3400 nM
Beside the measured number, compound 4's estimate is 1.6-fold (0.21 log units) above it; measured number inside the range.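

In this assay the new pair gives a step of a 7.6-fold lower number from compound 2 to compound 4 (0.88 log units; beyond the scatter) and so runs in the same direction as the earlier pair, with hydroxymethyl in place of carboxy giving the lower number on both cores. The size of the step also carries over, with no difference between the two cores that can be told from these numbers: the same change on two cores in this assay, a 5.5-fold lower number (0.74 log units; beyond the scatter) from compound 3 to compound 1 and a 7.6-fold lower number (0.88 log units; beyond the scatter) from compound 2 to compound 4, 1.4-fold (0.14 log units) apart, within the scatter of two such steps. For the compounds shown here, this rests on only two pairs, so it says nothing about further cores and does not show why the number falls on either core.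

The compounds shown leave open how an aminomethyl, a methoxymethyl or a primary carboxamide group on the same aromatic carbon would compare with hydroxymethyl on either core. They also leave open whether a longer chain, such as hydroxyethyl, would keep the lower number seen with hydroxymethyl.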